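Swapping the aryl group on a shared isoxazole-bearing core

The source may report more compounds than this note shows. Statements on the series, on what has been measured and on what is new or still open speak of the compounds shown alone.

Measured so far:
compound 1, `COc1ccc(-c2cc(CN(c3nc4ccc(F)cc4s3)c3nc4ccc(OC)cc4s3)on2)cc1`, 11400 nM
compound 2, `FC(F)(F)Oc1ccc(-c2cc(CN(c3ncccn3)c3nc4ccccc4s3)on2)cc1`, 5690 nM
compound 3, `COc1cc(-c2cc(CN(c3ncccn3)c3nc4ccccc4s3)on2)cc(OC)c1OC`, 10200 nM

Of the compounds shown here, three have been tested in a functional assay on COLO 205 cells (Homo sapiens) for antiproliferative activity, read by MTT assay; a higher number here means a weaker inhibitor, a lower number a stronger inhibitor. They share a core and differ in the aryl group carried on the five-membered ring. Compound 2 gives the lowest number of the three, but its gap to compound 3 and its gap to compound 1 both fall within the usual scatter of repeated measurements, so nothing can be said about which of the three is the stronger inhibitor.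

Compound 4, `Fc1ccccc1-c1cc(CN(c2ncccn2)c2nc3ccccc3s2)on1`, has not yet been measured. It differs from compound 2 in one place: 2-fluorophenyl in place of 4-(trifluoromethoxy)phenyl on an aromatic carbon. Among the measured compounds shown here, no measured pair in this set shows such a change, so there is no directly comparable step to lean on. The three known values all sit close together despite their different aryl groups, which suggests that a further change of the aryl group is unlikely to move the number far.

The expectation for compound 4 in this assay is therefore a step of a 1.4-fold higher number from compound 2 to compound 4 (0.15 log units; within the scatter), that is, no change beyond the scatter, possibly a slight weakening. The estimated value for compound 4 is 8000 nM, with a range from 3000 nM to 25000 nM.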

Compound 4, half-maximal inhibitory concentration: 13200 nM
Estimate against measurement, compound 4: 1.7-fold (0.22 log units) below; measured number inside the range.
By their numbers in this assay, from the lowest: compounds 2, 3, 1 and 4 (each within the scatter of the next, the first and the last beyond it).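

In this assay, among the compounds shown here, the aryl group on the aromatic carbon next to the ring nitrogen of the five-membered ring can shift the number, though only modestly: 2-fluorophenyl in place of 4-(trifluoromethoxy)phenyl gives a 2.3-fold higher number from compound 2 to compound 4 (0.37 log units; beyond the scatter) and is the one single-place step in this set. The change alters several things at once, as the entering group has fewer heavy atoms than the leaving group, no hydrogen-bond acceptor against 1, and a fluorine in place of the larger substituent on the phenyl ring, so this single step cannot show which of these differences matters. Nothing measured here accounts for the step.

The compounds shown leave open whether the weakening comes from losing the 4-(trifluoromethoxy) group or from bringing in the 2-fluoro group, a question that plain phenyl or 4-fluorophenyl at the same position could help to separate. Also open, as far as these compounds go, is how this position would respond to an aryl group carrying an amine or a carboxylic acid, since only ether and fluorine substituents appear on the aryl ring here.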